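Swapping an Ether Chain for a Branched Alkyl

The source may report more compounds than this note shows. Statements on the series, on what has been measured and on what is new or still open speak of the compounds shown alone.

Measured so far:
compound 1, `Nc1ccc2cccc(OC3CCC3)c2n1`: > 2000 nM (a limit of the assay)
compound 2, `COCC(C)Oc1cccc2ccc(N)nc12`: 606 nM
compound 3, `CCOCCOc1cccc2ccc(N)nc12`: > 2000 nM (a limit of the assay)

In an assay on cells with melanin-concentrating hormone receptor 1 (Homo sapiens) as the target, read by radioligand binding (on this read-out higher numbers stand for weaker inhibition and lower numbers for stronger inhibition), compound 3 reaches only the limit of the assay, > 2000 nM. Compound 1 likewise gives only a limit, > 2000 nM. Compound 2 gives 606 nM. The step of an at least 3.3-fold higher number from compound 2 to compound 3 (0.51 log units; beyond the scatter) is at least modest, so compound 3 stands at the weak end of the three. Compound 3 shares its limit with compound 1 (the limit of > 2000 nM in this assay, at which 2 of the 3 values shown sit). Compound 4, `CCC(C)COc1cccc2ccc(N)nc12`, differs from compound 3 by sec-butyl in place of ethoxymethyl on a saturated chain carbon bound to an oxygen on an aromatic ring. For the measured compounds named here, no measured step covers a chain without an acceptor; the step of an at least 3.3-fold lower number from compound 1 to compound 2 (0.51 log units; beyond the scatter) shows the number falling below the limit when a chain replaces the cyclobutyl, while the step that the two limits leave unreadable from compound 1 to compound 3 gives no reading. The expectation for compound 4 in this assay is therefore a step of an at least 1.3-fold lower number from compound 3 to compound 4 (0.12 log units; that floor lies within the scatter), held with wide uncertainty. The estimate for compound 4 is 1500 nM, within a range of 400 nM to 6000 nM.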

Compound 4, half-maximal inhibitory concentration: 36 nM
For compound 4 the middle estimate is 42-fold (1.62 log units) above the measured one; measured number outside the range, below it.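

In this assay, sec-butyl in place of ethoxymethyl on a saturated chain carbon bound to an oxygen on an aromatic ring gives an at least 55-fold lower number from compound 3 to compound 4 (1.74 log units; beyond the scatter), so this position can respond strongly to a change between two groups of equal heavy-atom count. The ether chain with a measurable value is also surpassed, with a 17-fold lower number from compound 2 to compound 4 (1.23 log units; beyond the scatter). Removing the ether oxygen from the chain does not by itself account for the gain: compound 1 has no ether oxygen in its cyclobutyl, and the change to 2-methylbutyl gives an at least 55-fold lower number from compound 1 to compound 4 (1.74 log units; beyond the scatter).

From the compounds shown here alone, how far compound 1 and compound 3 really lie from compound 4 stays open: the limit of > 2000 nM in this assay, at which 2 of the 4 values shown sit. Also open, going by these compounds, is whether a longer chain such as n-hexyl, or an amine at the end of the chain, would keep the value of compound 4.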